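The compounds below may be only part of what the source reports. "The series", "measured", "known", "first", "only" and "open" are said of these compounds alone.

Measured in a functional assay on A549 cells (Homo sapiens) for antiproliferative activity, read by MTT assay, with a stated time of 48 h; a lower number here means a stronger inhibitor, a higher number a weaker inhibitor:
- compound 1 `COc1ccc(C(=O)c2ccc(OC)c3c2OC(C)(C)C=C3)c(NC(=O)CBr)c1`: 1210 nM
- compound 2 `COc1ccc(C(=O)c2ccc(OC)c3c2OC(C)(C)C=C3)c(NC(=O)CN)c1`: 270 nM

Of these two, compound 2 has the lower number, 270 nM, which makes it the stronger inhibitor in this assay. Compound 3 `CNCC(=O)Nc1cc(OC)ccc1C(=O)c1ccc(OC)c2c1OC(C)(C)C=C2` has not yet been measured. It differs from compound 2 at a single place: methyl in place of hydrogen on an amine nitrogen.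

Among the compounds with values here, only one measured step touches this end of the chain: a 4.5-fold lower number from compound 1 to compound 2 (0.65 log units; beyond the scatter), where amino replaced bromo. That step shows that the number can move when this group changes. However, it is a different kind of swap, and no measured pair tests a methyl on the amine nitrogen. The expectation in this assay is therefore a step smaller than that one, probably none beyond the scatter, with neither direction clearly favoured.

That reasoning gives an expected 1.1-fold higher number from compound 2 to compound 3 (0.05 log units; within the scatter). For compound 3 the estimated value is 300 nM, with an expected range of 120 nM to 750 nM.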

Compound 3, half-maximal inhibitory concentration: 620 nM
Compound 3: middle estimate off by 2.1-fold (0.32 log units), on the low side; the range from low to high includes it.
By their numbers in this assay, from the lowest: compound 2; then compounds 3 and 1 (each within the scatter of the next).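

In this assay, the amine nitrogen proves sensitive to the smallest possible addition: a single methyl in place of hydrogen gives a 2.3-fold higher number from compound 2 to compound 3 (0.36 log units; beyond the scatter), so this position does not freely accept even one extra carbon. Set against the bromo compound, the methylamino group gives a 2.0-fold lower number from compound 1 to compound 3 (0.29 log units; within the scatter), which means that compound 3 cannot be told apart from compound 1, and the advantage that the plain amino group of compound 2 holds over bromo does not clearly carry over once the nitrogen bears a methyl. No measurement available here explains why the methyl has this effect.

The compounds shown leave open whether the number keeps rising as the nitrogen carries more carbon, for example with an ethylamino group, a dimethylamino group or a ring amine such as piperidine. They also leave open whether a longer chain ending in the same amino group, or a hydroxyl group in place of the amino group, would match compound 2 at 270 nM.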